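Bromo added to the hydroxyphenyl of compound 1

The compounds below may be only part of what the source reports. "The series", "measured", "known", "first", "only" and "open" are said of these compounds alone.

Compound 1 `Cn1c(=O)c(=O)n(C2CCCC2)c2nc(N/N=C/c3ccc(O)cc3)ncc21` is the weaker of the two measured compounds in a functional assay on HCT-116 cells (Homo sapiens) for antiproliferative activity, read by MTT assay (a higher number here means a weaker inhibitor, a lower number a stronger inhibitor), where compound 1 gives 72500 nM. Among the compounds with values here, its only measured neighbour, compound 2 `Cn1c(=O)c(=O)n(C2CCCC2)c2nc(N/N=C/c3cccc([N+](=O)[O-])c3)ncc21`, gives 15200 nM in this assay; the step of a 4.8-fold lower number from compound 1 to compound 2 (0.68 log units; beyond the scatter) swaps the whole aryl substitution and so says little about a single added halogen. Compound 3 `Cn1c(=O)c(=O)n(C2CCCC2)c2nc(N/N=C/c3ccc(O)c(Br)c3)ncc21` differs from compound 1 by bromo in place of hydrogen on an aromatic carbon. Within the data shown here, no measured pair shows this change on its own, so the size of the step is uncertain; the one step that exists shows that the aryl substitution can matter, but the hydroxy group is kept here. Compound 3 is therefore expected to give a number near that of compound 1, with a modest lower value considered plausible, in the range 15000 nM to 130000 nM around an estimate of 45000 nM, which corresponds to an expected step of a 1.6-fold lower number from compound 1 to compound 3 (0.21 log units; within the scatter).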

Compound 3, half-maximal inhibitory concentration: 17700 nM
Compound 3: middle estimate off by 2.5-fold (0.41 log units), on the high side; the measured number falls inside the stated range.
By their numbers in this assay, from the lowest: compounds 2 and 3 (each within the scatter of the next); then compound 1.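

In this assay, bromo in place of hydrogen on the aromatic carbon ortho to a hydroxy group gives a 4.1-fold lower number from compound 1 to compound 3 (0.61 log units; beyond the scatter), so a single heavy atom at this position moves the number while the hydroxy group stays in place. The earlier step exchanged the whole aryl substitution, whereas this change keeps the 4-hydroxyphenyl and adds only bromo, and the exchange of the 3-nitrophenyl for 3-bromo-4-hydroxyphenyl gives a 1.2-fold higher number from compound 2 to compound 3 (0.07 log units; within the scatter). No measurement shown here accounts for the effect of the bromo.

The compounds shown leave open whether this step belongs to bromo itself or would also follow with chloro, methyl or methoxy on the same carbon. They also leave open whether the hydroxy group still matters once bromo is present, and what an amine in its place would give.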